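One Methoxy, Two Places: Reading Across a Small Series

The source may hold more compounds than are shown below. What is called first, only, known or untested is meant among the compounds shown, and "the series" means these compounds.

Compound 1 `CC1=CC[C@H](C(C)(C)NC(=S)N/N=C/c2ccc(O)cc2)CC1` and compound 2 `COc1cc(/C=N/NC(=S)NC(C)(C)[C@H]2CC=C(C)CC2)ccc1O` differ in one place, (methoxy in place of hydrogen on an aromatic carbon). In an ADME assay on Vero cells (Chlorocebus sabaeus) for inhibition, read by sulforhodamine B assay, with a stated time of 48 h (a higher number here means a weaker inhibitor of growth, a lower number a stronger inhibitor of growth), compound 1 gives > 100000 nM, which is a limit of the assay and not a number. In this assay compound 2 gives 19700 nM. Going by these compounds, the step is an at least 5.0-fold lower number from compound 1 to compound 2 (0.70 log units; beyond the scatter); its full size stays open because the limit of > 100000 nM in this assay, at which 2 of the 3 values shown sit, is where compound 1 sits.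

Compound 3 `CC1=CC[C@H](C(C)(C)NC(=S)N/N=C(\C)c2ccccc2)CC1` has a different core, and the difference between the two cores is not broken down here. In this assay compound 3 gives > 100000 nM, again a limit. Compound 4 `COc1ccc(/C(C)=N/NC(=S)NC(C)(C)[C@H]2CC=C(C)CC2)cc1`, not yet measured, carries methoxy in place of hydrogen on an aromatic carbon. Within the data shown here, this is the same kind of change as the one between compound 1 and compound 2, not the same: there the methoxy sat ortho to a hydroxy group and meta to a large group, here it sits para to a large group. Resting on that single example, the step expected here is an at least 2.0-fold lower number from compound 3 to compound 4 (0.30 log units; that floor lies within the scatter), a thin basis on a different core. Compound 4 is therefore expected to give about 50000 nM, with a plausible range from 10000 nM to 200000 nM in this assay.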

Compound 4, concentration for 50% growth inhibition: > 100000 nM
Compound 4: no number, only a limit; the forecaster's own chance of this, stated with the estimate: 50%; at least 2.0-fold (0.30 log units) between middle value and limit.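

Compound 3 and compound 4 both give only a limit of the assay and not a number, so no step can be read between them: the limit of > 100000 nM in this assay, at which 3 of the 4 values shown sit.

The compounds shown leave open whether methoxy in place of hydrogen changes the number at all on the core of compound 3, and where the true values of compound 3 and compound 4 lie.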